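The compounds below may be only part of what the source reports. "The series", "measured", "known", "first", "only" and "open" are said of these compounds alone.

Going by the values given here, in an ADME assay on HepG2 cells (Homo sapiens) for cytotoxicity, read by luminescence, CellTiter-Glo and ATP content, with a stated time of 72 h (on this read-out higher numbers stand for an effect only at larger amounts of compound and lower numbers for an effect already at smaller amounts), compound 1 `COc1ccc(F)cc1CNCCCNc1ccnc2cc(Cc3ccc(F)cc3Cl)ccc12` gives 2460 nM and compound 2 `COc1ccc(F)cc1CNCCCNc1ccnc2cc(CCC(C)C)ccc12` gives 890 nM, which makes compound 2 the lower of the two numbers so far. Compound 3 `COc1ccc(F)cc1CNCCCNc1ccnc2cc(-c3ccc(C(C)(C)C)cc3)ccc12` is not yet measured. Its change from compound 2 is 4-(tert-butyl)phenyl in place of isopentyl on an aromatic carbon. Among the compounds with values here, only one measured step bears on this, and only loosely: a 2.8-fold lower number from compound 1 to compound 2 (0.44 log units; beyond the scatter), where isobutyl took the place of 2-chloro-4-fluorophenyl on a saturated chain carbon. Compound 3 regains an aromatic ring at this end, but bound directly to an aromatic carbon, so a modest step towards a higher number is expected, of similar size or smaller. The expected step is a 1.5-fold higher number from compound 2 to compound 3 (0.16 log units; within the scatter) and may not clear the scatter. The estimate for compound 3 is 1300 nM, with an expected range from 450 nM to 3500 nM.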

Compound 3, half-maximal effective concentration: 620 nM
Beside the measured number, compound 3's estimate is 2.1-fold (0.32 log units) above it; the measured number falls inside the stated range.
By their numbers in this assay, from the lowest: compounds 3 and 2 (each within the scatter of the next); then compound 1.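

In this assay, the step with 4-(tert-butyl)phenyl in place of isopentyl on this aromatic carbon is a 1.4-fold lower number from compound 2 to compound 3 (0.16 log units; within the scatter) and lies within the scatter, so a directly bound aromatic ring and this saturated chain are not separated on this read-out. An aromatic ring at this position therefore does not by itself go with the high number of compound 1, as 4-(tert-butyl)phenyl in place of 2-chloro-4-fluorobenzyl gives a 4.0-fold lower number from compound 1 to compound 3 (0.60 log units; beyond the scatter) and this step lies beyond the scatter. No measurement shown here accounts for these numbers.

The step between compound 1 and compound 3 changes both the saturated carbon link and the ring substituents, so the compounds shown do not separate these two changes. On these data alone, a 4-(tert-butyl)benzyl group would test this directly, while the effect of an amine or a carboxylic acid at this position remains open.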